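The compounds below may be only part of what the source reports. "The series", "measured", "known", "first", "only" and "open" are said of these compounds alone.

Measured so far in a functional assay on MDA-MB-231 cells (Homo sapiens) for antiproliferative activity, read by CCK-8 assay, with a stated time of 72 h; on this read-out lower numbers stand for stronger inhibition and higher numbers for weaker inhibition:
compound 1 `O=C(Nc1cccc(-c2oc3cc(-c4ccc(F)cc4)ccc3c(=O)c2O)c1)c1ccccc1F` — 7240 nM
compound 2 `COc1ccc(C(=O)Nc2cccc(-c3oc4cc(-c5ccc(F)cc5)ccc4c(=O)c3O)c2)cc1` — 16500 nM
compound 3 `Cc1ccccc1C(=O)Nc1cccc(-c2oc3cc(-c4ccc(F)cc4)ccc3c(=O)c2O)c1` — 4910 nM

Compound 1 holds the second highest of the three numbers. Compound 3 is nearest, with a 1.5-fold lower number from compound 1 to compound 3 (0.17 log units; within the scatter), and compound 2 is furthest, with a 2.3-fold higher number from compound 1 to compound 2 (0.36 log units; beyond the scatter). Between the other two the step is a 3.4-fold lower number from compound 2 to compound 3 (0.53 log units; beyond the scatter).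

Compound 4 `O=C(Nc1cccc(-c2oc3cc(-c4ccc(F)cc4)ccc3c(=O)c2O)c1)c1ccc(Br)cc1` differs from compound 1 as follows: 4-bromophenyl in place of 2-fluorophenyl on a carbonyl carbon. Among the compounds with values here, the one measured step starting from the same 2-fluorophenyl on the carbonyl carbon, a 2.3-fold higher number from compound 1 to compound 2 (0.36 log units; beyond the scatter), brought in 4-methoxyphenyl and gave a modest rise; 4-bromophenyl itself has no measured counterpart, and bromine is not methoxy, so that direction carries over only loosely. Compound 3 shows a ring change at the same place, 2-methylphenyl, that stays within the scatter. The expectation for compound 4 is therefore a small step toward a higher number, at or just beyond the scatter, a 1.4-fold higher number from compound 1 to compound 4 (0.14 log units; within the scatter). The estimate for compound 4 in this assay is 10000 nM, with a range from 4000 nM to 25000 nM.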

Compound 4, half-maximal inhibitory concentration: 24900 nM
The estimate for compound 4 lay 2.5-fold (0.40 log units) below the measured number, and the stated range covers the measured number.
By their numbers in this assay, from the lowest: compounds 3 and 1 (each within the scatter of the next); then compounds 2 and 4 (each within the scatter of the next).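

In this assay, 4-bromophenyl on the carbonyl carbon gives a loss in two steps: a 3.4-fold higher number from compound 1 to compound 4 (0.54 log units; beyond the scatter) and a 5.1-fold higher number from compound 3 to compound 4 (0.71 log units; beyond the scatter). Bromo in place of methoxy on an aromatic carbon, by contrast, stays within the scatter: a 1.5-fold higher number from compound 2 to compound 4 (0.18 log units; within the scatter).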